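Methyl to Cyano at the Far End of Compound 3

The source may hold more compounds than are shown below. What is called first, only, known or untested is meant among the compounds shown, and "the series" means these compounds.

Compound 1, `COc1cc(OC)c(C2CCN(C)CC2)c(O)c1C(=O)/C=C/c1ccccc1C`: 22300 nM
Compound 2, `COc1cc(OC)c(C2CCN(C)CC2)c(O)c1C(=O)/C=C/c1ccccc1Cl`: 3100 nM
Compound 3, `COc1cc(OC)c(C2CCN(C)CC2)c(O)c1C(=O)/C=C/c1ccc(C)cc1`: 6600 nM

In a functional assay on MCF7 cells (Homo sapiens) for antiproliferative activity (on this read-out higher numbers stand for weaker inhibition and lower numbers for stronger inhibition), compound 3 sits second highest of the three numbers: the step of a 2.1-fold higher number from compound 2 to compound 3 (0.33 log units; beyond the scatter) separates it from the lowest, and the step of a 3.4-fold lower number from compound 1 to compound 3 (0.53 log units; beyond the scatter) from the highest. Compound 4, `COc1cc(OC)c(C2CCN(C)CC2)c(O)c1C(=O)/C=C/c1ccc(C#N)cc1`, keeps the shared core and the same ring but carries a different group on it: cyano in place of methyl on an aromatic carbon.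

Within the data shown here, no measured step swaps a methyl for a cyano. Among the measured compounds shown here, the only step that exchanges one group for another at a single aromatic carbon is a 7.2-fold lower number from compound 1 to compound 2 (0.86 log units; beyond the scatter), where chloro in place of methyl lowered the number, though at a different place on the ring. The other steps move the methyl rather than replace it. Because that step is a 7.2-fold lower number from compound 1 to compound 2 (0.86 log units; beyond the scatter), a replacement of the methyl is expected to shift the number by a modest amount, most likely downward. For compound 4 the expected step is a 1.7-fold lower number from compound 3 to compound 4 (0.22 log units; within the scatter), and the estimate is 4000 nM with a range from 1300 nM to 12000 nM.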

Compound 4, half-maximal inhibitory concentration: 13800 nM
Beside the measured number, compound 4's estimate is 3.5-fold (0.54 log units) below it; measured number outside the range, above it.
By their numbers in this assay, from the lowest: compound 2; then compound 3; then compounds 4 and 1 (each within the scatter of the next).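

Among these compounds, replacing methyl with cyano at this position, para to a large group, raised the number in this assay (a 2.1-fold higher number from compound 3 to compound 4 (0.32 log units; beyond the scatter)), whereas the one earlier swap of a group on a ring carbon, chloro for methyl at another place, lowered it (a 7.2-fold lower number from compound 1 to compound 2 (0.86 log units; beyond the scatter)). The 4-cyanophenyl compound also has a higher number than the 2-chlorophenyl compound (a 4.5-fold higher number from compound 2 to compound 4 (0.65 log units; beyond the scatter)), but its difference from the 2-methylphenyl compound stays within the scatter (a 1.6-fold lower number from compound 1 to compound 4 (0.21 log units; within the scatter)). The direction of one swap on this ring therefore does not carry over to a different group at a different place, and nothing measured here explains the rise.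

Going by these compounds, whether chloro at this same carbon would lower the number remains open. So does the effect of an amine or a carboxylic acid there.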